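The compounds below may be only part of what the source reports. "The series", "measured", "known", "first", "only" and "open" are said of these compounds alone.

Measured in a functional assay on DU-145 cells (Homo sapiens) for antiproliferative activity, read by WST assay, with a stated time of 72 h; on this read-out lower numbers stand for an effect already at smaller amounts and higher numbers for an effect only at larger amounts of compound:
Compound 1 `CCCCCCCC/C=C\c1c(C)nc(C)c(/C=C\CCCCCCCC)c1C` gives > 30 uM
Compound 2 `CCCCCCCCCCc1c(C)c(CCCCCCCCCC)c2[n+](c1C)CCC2` gives 1.3 uM

The entry for compound 1 is a limit of the assay and not a number: > 30 uM. For the measured compounds named here, compound 2, at 1.3 uM, therefore holds the only actual number in this assay, so it has no measured neighbour to be ranked against.

Compound 3 `CCCCCCCCCCc1c(C)cc2[n+](c1C)CCC2` has not yet been measured. It differs from compound 2 in one place: hydrogen in place of decyl on an aromatic carbon. Hydrogen stands in place of decyl on an aromatic carbon, and the other decyl group stays. Going by the values given here, no measured step between single-place neighbours is available to size this change, so the expectation rests on compound 2 at 1.3 uM and on the change itself. A moderate shift towards larger amounts is expected, beyond the usual scatter, with an estimated 4.6-fold higher number from compound 2 to compound 3 (0.66 log units; beyond the scatter). For compound 3 the estimated value is 6 uM. The expected range runs from 1.5 uM to 25 uM.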

Compound 3, concentration for half-maximal effect: 1.6 uM
The estimate for compound 3 lay 3.8-fold (0.57 log units) above the measured number; low and high end bracket the measured number.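

In this assay, putting hydrogen in place of decyl on the aromatic carbon ortho to a methyl group gives a 1.2-fold higher number from compound 2 to compound 3 (0.09 log units; within the scatter), so the two compounds cannot be told apart on this read-out. For the compounds shown here, this is the first sized change at this position, and it shows that a decyl group of 10 heavy atoms can leave this carbon without a difference beyond the usual scatter, as long as the other decyl group stays. Nothing shown here accounts for why this position tolerates the loss of the chain.

Going by these compounds, whether a butyl chain, an amine or a carboxylic acid on this same carbon would also read like compound 3 remains open. On these data alone, it also remains open whether the remaining decyl group could give way to hydrogen in the same manner.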